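This account rests on a few compounds, and the source may have more. Where it says the series, first, only, none or still open, it means among the compounds named here.

In a functional assay on MDA-MB-231 cells (Homo sapiens) for antiproliferative activity, read by MTT assay, with a stated time of 24 h (a higher number here means a weaker inhibitor, a lower number a stronger inhibitor), compound 1 (`O=C(O)CC(NC(=O)c1cccc(Br)c1)c1ccccc1`) reads > 100000 nM as a limit and not a number. Compound 2 (`O=C(O)CC(NS(=O)(=O)c1ccc(OC(F)(F)F)cc1)c1ccccc1`) reads > 100000 nM and this too is only a limit. Among the compounds with values here, compound 3 (`CC(C)(C)c1ccc(C(CC(=O)O)NC(=O)c2ccc(Cl)cc2Cl)cc1`) gives 67800 nM as the one true number so far. Within the data shown here, compound 1 therefore sits on the limit of > 100000 nM in this assay, at which 2 of the 3 values shown sit, and has no measured step to any neighbour.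

Compound 4 (`O=C(O)CC(NC(=O)c1cccc(Br)c1)c1ccccc1F`) is compound 1 with fluoro in place of hydrogen on an aromatic carbon, a change of phenyl to 2-fluorophenyl, ortho to a large group. Among the measured compounds shown here, no measured pair shows what this change does in this assay so the expectation rests only on the standing of compound 1 and the single added atom. The expected step that the limit leaves unreadable from compound 1 to compound 4 is none beyond the scatter, in neither direction. For compound 4 the estimated value is 120000 nM with an expected range from 60000 nM to 250000 nM and another report as a limit is the likeliest outcome.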

Compound 4, half-maximal inhibitory concentration: > 100000 nM
Compound 4 ended at the assay's limit (the forecaster's own chance of this, stated with the estimate: 75%); the middle value is on the limit's open side.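

In this assay no step can be read between compound 1 and compound 4, because both are reported only as limits: the limit of > 100000 nM in this assay, at which 3 of the 4 values shown sit.

The compounds shown leave open what fluoro in place of hydrogen on an aromatic carbon does to antiproliferative activity on a core that gives a true number.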